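Moving the methoxy group on the sulfonyl aryl ring

The compounds below may be only part of what the source reports. "The series", "measured", "known", "first", "only" and "open" are said of these compounds alone.

compound 1, `CCc1ccc(S(=O)(=O)Nc2ccc(-c3nc4ccccc4o3)cc2)cc1`: 82000 nM
compound 2, `COc1ccccc1S(=O)(=O)Nc1ccc(-c2nc3ccccc3o2)cc1`: > 100000 nM

Of the compounds shown here, two have been measured in an ADME assay on HEK293 cells (Homo sapiens) for cytotoxicity, read by resazurin assay, with a stated time of 48 h; a lower number here means that less compound is tolerated, a higher number that more compound is tolerated. Compound 1 gives 82000 nM. Compound 2 returns > 100000 nM, which is a limit of the assay and not a number, as the line the limit of > 100000 nM in this assay, at which 1 of the 2 values shown sits, records. Compound 2 thus stands at the upper edge of what this assay can report, with only a limit for it and no numerical value. Within the data shown here, the single measured step, an at least 1.2-fold higher number from compound 1 to compound 2 (0.08 log units; that floor lies within the scatter), also changes the group on the sulfonyl sulfur, and its floor lies within the scatter.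

Compound 3 `COc1cccc(S(=O)(=O)Nc2ccc(-c3nc4ccccc4o3)cc2)c1` is the next compound. It differs from compound 2 by 3-methoxyphenyl in place of 2-methoxyphenyl on a sulfonyl sulfur. Among the measured compounds shown here, the one measured step bears on it only loosely, since it too alters the sulfonyl aryl group, and it showed no step beyond the scatter. For compound 3 in this assay no step beyond the scatter is therefore expected, and the expected step of a number no higher from compound 2 to compound 3 (the limit leaves the size open) is essentially flat. Compound 3 is estimated at 100000 nM, with a range of 50000 nM to 200000 nM.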

Compound 3, half-maximal cytotoxic concentration: > 100000 nM
Compound 3: only a limit was reported; the forecaster's own chance of this, stated with the estimate: 55%; the middle value lies on the limit itself.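

In this assay compound 3 returns > 100000 nM, which is a limit of the assay and not a number. The new result shows that the methoxy group can stand in the 3-methoxyphenyl as well as the 2-methoxyphenyl arrangement on the sulfonyl sulfur with both compounds reported only as a limit, and the step between compound 2 and compound 3 cannot be read, so moving the methoxy group has no size that can be stated here: the limit of > 100000 nM in this assay, at which 2 of the 3 values shown sit. Set against the 4-ethylphenyl group, the 3-methoxyphenyl group gives an at least 1.2-fold higher number from compound 1 to compound 3 (0.08 log units; that floor lies within the scatter), so this comparison, like the earlier one for the 2-methoxyphenyl group, shows no change that can be told apart from the scatter.

As far as these compounds go, how far compound 2 and compound 3 really lie past the limit, and whether they differ from each other at all, stays open. Also open, from the compounds shown here alone, is how this assay would read with an amine or a carboxylic acid on the sulfonyl aryl ring, or with a longer chain in place of the methoxy group, and whether any such change would bring a value back inside the measurable range.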